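The source may hold more compounds than are shown below. What is called first, only, known or untested is meant among the compounds shown, and "the series" means these compounds.

Measured so far in a functional assay on cells for antagonist activity at Free fatty acid receptor 1 (Homo sapiens), read by TR-FRET and inositol phosphate accumulation, with a stated time of 2 h; on this read-out lower numbers stand for stronger inhibition and higher numbers for weaker inhibition:
compound 1 `Cc1cc(COc2ccccc2)nc(-c2ccccn2)n1` gives 794 nM.
compound 2 `Cc1cc(COc2cccc(Cl)c2)nc(-c2ccccn2)n1` gives 398 nM.
compound 3 `CC(=O)Nc1cccc(OCc2cc(C)nc(-c3ccccn3)n2)c1` gives only the limit > 39800 nM.

Compound 3 thus stands at the edge of what this assay reports; its value is a limit and not a number (the limit of > 39800 nM in this assay, at which 1 of the 3 values shown sits). The two steps that reach it, an at least 50-fold higher number from compound 1 to compound 3 (1.70 log units; beyond the scatter) and an at least 100-fold higher number from compound 2 to compound 3 (2.00 log units; beyond the scatter), are both large and beyond the scatter, so among the three measured compounds compound 3 is the weakest. The step of a 2.0-fold lower number from compound 1 to compound 2 (0.30 log units; within the scatter), by contrast, is within the scatter.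

Compound 4 `Cc1cc(COc2cccc(S(C)(=O)=O)c2)nc(-c2ccccn2)n1` differs from compound 3 by methylsulfonyl in place of acetamido on an aromatic carbon. Going by the values given here, the only measured steps that bear on this position are the two that introduce acetamido, and both show that acetamido raises the number markedly. Among the compounds with values here, compound 4 sheds acetamido but takes on methylsulfonyl, a group of the same heavy-atom count at the same place; no measured step covers methylsulfonyl itself, so the direction is open. Because compound 3 is only a limit, the step from compound 3 to compound 4 is expected to be a lowering of uncertain size, an at least 3.9-fold lower number from compound 3 to compound 4 (0.59 log units; beyond the scatter), with a fair chance that compound 4 also returns only a limit. The estimate for compound 4 is 10000 nM, in the range 1500 nM to 60000 nM.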

Compound 4, half-maximal inhibitory concentration in the Free fatty acid receptor 1 assay: > 39800 nM
Compound 4: a limit, no number; the forecaster's own chance of this, stated with the estimate: 40%; at least 3.9-fold (0.59 log units) between middle value and limit.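

In the Free fatty acid receptor 1 assay compound 4, which carries methylsulfonyl and no hydrogen-bond donor, gives > 39800 nM, a limit and not a number. The loss at this position is thus not confined to acetamido: the Free fatty acid receptor 1 assay shows an at least 50-fold higher number from compound 1 to compound 4 (1.70 log units; beyond the scatter) and an at least 100-fold higher number from compound 2 to compound 4 (2.00 log units; beyond the scatter). The step between compound 3 and compound 4 cannot be read, since both stand at a limit and not at a number: the limit of > 39800 nM in the Free fatty acid receptor 1 assay, at which 2 of the 4 values shown sit. In a physicochemical assay for lipophilicity, at pH 7.4 (on this read-out lower numbers stand for lower lipophilicity and higher numbers for higher lipophilicity), compound 3 gives 2.1 and compound 4 gives 1.7. The same exchange does register in the physicochemical assay, with a number 0.40 log units lower from compound 3 to compound 4 (beyond the scatter), whereas the Free fatty acid receptor 1 assay gives no number for either compound and so cannot show whether this difference has any bearing on inhibition.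

Open, going by these compounds, is whether a methoxy group, a nitrile or an amine on the same aromatic carbon would stay in the range of compound 1 and compound 2 or also fall to the limit. Also open, on these data alone, is whether a carboxylic acid or a longer chain there would return a number, which would show how much of this position tolerates substitution beyond chloro.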